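The source may hold more compounds than are shown below. What is called first, only, known or untested is meant among the compounds shown, and "the series" means these compounds.

In a functional assay on HCT-116 cells (Homo sapiens) for antiproliferative activity, read by MTT assay, with a stated time of 48 h (a lower number here means a stronger inhibitor, a higher number a weaker inhibitor), three compounds have been measured. Compound 1 (`COc1ccc(-c2cc3c(cn2)[nH]c(=O)n3-c2cc(OC)c(OC)c(OC)c2)cc1F`) gives 910 nM. Compound 2 (`CCOc1ccc(-c2cc3c(cn2)[nH]c(=O)n3-c2cc(OC)c(OC)c(OC)c2)cc1`) gives 6660 nM. Compound 3 (`COc1ccc(-c2cc3c([nH]c(=O)n3-c3cc(OC)c(OC)c(OC)c3)c(C(N)=O)n2)cc1F`) gives 360 nM, the lowest of the three numbers and so the strongest inhibitor of the set.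

Compound 4 (`CCOc1ccc(-c2cc3c([nH]c(=O)n3-c3cc(OC)c(OC)c(OC)c3)c(C(N)=O)n2)cc1`) has not yet been measured. It differs from compound 3 in one place: 4-ethoxyphenyl in place of 3-fluoro-4-methoxyphenyl on an aromatic carbon. There, 4-ethoxyphenyl stands in place of 3-fluoro-4-methoxyphenyl, on an aromatic carbon next to the ring nitrogen.

The same exchange has been measured once, in a pair without the carbamoyl group, and it gave a 7.3-fold higher number from compound 1 to compound 2 (0.86 log units; beyond the scatter). Putting carbamoyl in place of hydrogen gave a 2.5-fold lower number from compound 1 to compound 3 (0.40 log units; beyond the scatter). Both steps are modest but beyond the scatter. A single pair is thin evidence, and the exchange may not behave the same way alongside the carbamoyl group. Even so, a similar step toward a higher number is expected in this assay. The expected change is a 6.4-fold higher number from compound 3 to compound 4 (0.81 log units; beyond the scatter). The estimate for compound 4 is 2300 nM, with an expected range of 800 nM to 6500 nM.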

Compound 4, half-maximal inhibitory concentration: 13300 nM
For compound 4 the middle estimate is 5.8-fold (0.76 log units) below the measured one, outside the stated range (above it).
By their numbers in this assay, from the lowest: compound 3; then compound 1; then compounds 2 and 4 (each within the scatter of the next).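

In this assay, the exchange of 3-fluoro-4-methoxyphenyl for 4-ethoxyphenyl gives a 37-fold higher number from compound 3 to compound 4 (1.57 log units; beyond the scatter) when the carbamoyl group is present, so the size of this step depends on the rest of the molecule: the same change on two cores in this assay, a 7.3-fold higher number (0.86 log units; beyond the scatter) from compound 1 to compound 2 and a 37-fold higher number (1.57 log units; beyond the scatter) from compound 3 to compound 4, 5.0-fold (0.70 log units) apart, beyond the scatter of two such steps. The carbamoyl group does not bring a fixed change either, since alongside 4-ethoxyphenyl it gives a 2.0-fold higher number from compound 2 to compound 4 (0.30 log units; within the scatter), whereas alongside 3-fluoro-4-methoxyphenyl it lowered the number: the same change on two cores in this assay, a 2.5-fold lower number (0.40 log units; beyond the scatter) from compound 1 to compound 3 and a 2.0-fold higher number (0.30 log units; within the scatter) from compound 2 to compound 4, 5.0-fold (0.70 log units) apart, beyond the scatter of two such steps. The two changes therefore do not simply add up, and the lower number with the carbamoyl group appears only with 3-fluoro-4-methoxyphenyl.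

The exchange alters the fluorine and the alkoxy chain together, so these compounds cannot separate the two; a phenyl group carrying methoxy without fluorine would do so. As far as these compounds go, whether a carboxylic acid or an amine in place of the carbamoyl group behaves the same way also remains open.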